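A few compounds are considered here, and "the series" means these few. Any claim that something is new, unique, unknown or untested is made for them only; others in the source may bear on it.

Compound 1 `Oc1cccc(-c2cc(-c3ccccc3C(F)(F)F)cc(-c3ccccc3O)n2)c1` gives 7250 nM in a functional assay on DU-145 cells (Homo sapiens) for inhibition; on this read-out higher numbers stand for weaker inhibition and lower numbers for stronger inhibition.
Compound 2 `Oc1ccc(-c2cc(-c3ccccc3C(F)(F)F)cc(-c3ccccc3O)n2)cc1` gives 6690 nM in this assay.
Compound 3 `Oc1cccc(-c2cc(-c3cccc(OC(F)(F)F)c3)cc(-c3cccc(O)c3)n2)c1` gives only a limit in this assay, reported as > 50000 nM.

Compounds 1 and 2 share one core and differ in a single place: 4-hydroxyphenyl in place of 3-hydroxyphenyl on an aromatic carbon. In this assay this change gave a 1.1-fold lower number from compound 1 to compound 2 (0.03 log units; within the scatter), so the two values cannot be told apart.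

Compound 3 has a different core, and how its core differs from that of compound 1 is not broken down here. For compound 3 this assay reports no number but (the limit of > 50000 nM in this assay, at which 1 of the 3 values shown sits).

Compound 4 `Oc1ccc(-c2cc(-c3cccc(OC(F)(F)F)c3)cc(-c3cccc(O)c3)n2)cc1` has not yet been measured. It differs from compound 3 in one place: 4-hydroxyphenyl in place of 3-hydroxyphenyl on an aromatic carbon. Going by the values given here, this is the same kind of change as the one from compound 1 to compound 2, though the surroundings are not identical: in compounds 1 and 2 the place is meta to a 2-(trifluoromethyl)phenyl group and meta to a 2-hydroxyphenyl group, whereas in compounds 3 and 4 it is meta to a 3-hydroxyphenyl group and meta to a large group.

Since the same kind of change gave a 1.1-fold lower number from compound 1 to compound 2 (0.03 log units; within the scatter), a step of similar small size is expected here, namely a step that the limit leaves unreadable from compound 3 to compound 4. Compound 4 is therefore expected to sit near the limit of compound 3, at about 60000 nM in this assay, with a range from 25000 nM to 150000 nM, and it may well be reported only as a limit again.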

Compound 4, half-maximal inhibitory concentration: 5670 nM
Compound 4: the middle estimate sits 11-fold (1.02 log units) above what was measured; the measured number lies below the stated range.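

In this assay, putting 4-hydroxyphenyl in place of 3-hydroxyphenyl gave an at least 8.8-fold lower number from compound 3 to compound 4 (0.94 log units; beyond the scatter), and that figure is a floor on the size of the step, not its measured size. The change therefore does not carry over from one core to the other with the same size, and the two steps can be told apart: the same change on two cores in this assay, a 1.1-fold lower number (0.03 log units; within the scatter) from compound 1 to compound 2 and an at least 8.8-fold lower number (0.94 log units; beyond the scatter) from compound 3 to compound 4, at least 8.1-fold (0.91 log units) apart, beyond the scatter of two such steps. This does not show which feature of the two cores accounts for the gap, as the way they differ is not broken down here, and two pairs of compounds are too few to support a rule that reaches beyond these four compounds.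

One open question is how large the step from the core of compound 3 really is, which only a number in place of its limit in this assay could settle. On these data alone, it also remains open whether the result depends on the hydroxyl group itself, which an amine or a carboxylic acid at the same place on the ring would help to test on both cores.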